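Compound 3: methyl in place of hydrogen on an aromatic oxygen

The source may report more compounds than this note shows. Statements on the series, on what has been measured and on what is new or still open speak of the compounds shown alone.

In a functional assay on H266 cells (Homo sapiens) for cytotoxicity, read by resazurin assay, with a stated time of 72 h (a higher number here means a weaker inhibitor, a lower number a stronger inhibitor), compound 1 `COc1cc(/C=C/C(=O)OCCCCCCO[N+](=O)[O-])ccc1O` reads > 50000 nM as a limit of the assay and not a number.

In this assay, within the data shown here, compound 2 `O=C(/C=C/c1ccc(O)c(O)c1)OCc1c(-c2ccccc2)no[n+]1[O-]` gives 14200 nM as the only true number so far, so it has no measured neighbour to be ranked against.

Compound 3 `COc1cc(/C=C/C(=O)OCc2c(-c3ccccc3)no[n+]2[O-])ccc1O` keeps the core of compound 2, with methyl in place of hydrogen on an oxygen on an aromatic ring so that 3,4-dihydroxyphenyl becomes 4-hydroxy-3-methoxyphenyl. Among the measured compounds shown here, no measured pair isolates this change.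

Compound 1 also holds the 4-hydroxy-3-methoxyphenyl group and has > 50000 nM as its limit, but its ester part differs too, so it offers only a weak hint of direction.

In this assay a small move towards a higher number is therefore expected, near the usual scatter in size. The expected step of a 1.4-fold higher number from compound 2 to compound 3 (0.15 log units; within the scatter) would leave the compound a weak inhibitor.

In this assay the estimate for compound 3 is 20000 nM with 7000 nM to 50000 nM as the expected range.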

Compound 3, half-maximal inhibitory concentration: 13400 nM
Compound 3: middle estimate off by 1.5-fold (0.17 log units), on the high side; low and high end bracket the measured number.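

In this assay, methyl in place of hydrogen on an oxygen on an aromatic ring now has a measured pair, and the change from 3,4-dihydroxyphenyl to 4-hydroxy-3-methoxyphenyl reads as a 1.1-fold lower number from compound 2 to compound 3 (0.03 log units; within the scatter) in this series. At this position, hydroxy to methoxy therefore leaves the number within the scatter, so one free hydroxy is not needed to keep the value of compound 2 on the shared core. Compound 1 carries the same 4-hydroxy-3-methoxyphenyl group, but its value is a limit of the assay and not a number, and steps involving it cannot be read: the limit of > 50000 nM in this assay, at which 1 of the 3 values shown sits.

Open, on these data alone, is whether the same flat reading holds for a larger group on this oxygen, such as ethoxy or benzyloxy, or for an amine or a carboxylic acid in place of the hydroxy. Also open, as far as these compounds go, is how the number moves when the remaining hydroxy is replaced, or when an amide or a longer chain replaces the ester part, since each of these would need a measured neighbour of compound 3 that differs in one place.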